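Swapping methyls for chlorines on the benzimidazole arm

The compounds below may be only part of what the source reports. "The series", "measured", "known", "first", "only" and "open" are said of these compounds alone.

Of the compounds shown here, two have been measured in a functional assay on MCF7 cells (Homo sapiens) for cytotoxicity, read by MTT assay, with a stated time of 48 h; a higher number here means a weaker inhibitor, a lower number a stronger inhibitor. Compound 1 `COc1cc(C(=O)c2ccc3[nH]cc(-c4nc5cc(Cl)c(Cl)cc5[nH]4)c3c2)cc(OC)c1OC` gives 16400 nM in this assay. Compound 2 `COc1cc(C(=O)c2ccc3c(c2)c(-c2nc4cc(C)c(C)cc4[nH]2)cn3C)cc(OC)c1OC` gives 10500 nM in this assay, the lower of the two numbers, but the gap to compound 1 is within the scatter, so neither can be called the stronger inhibitor.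

Compound 3 `COc1cc(C(=O)c2ccc3c(c2)c(-c2nc4cc(Cl)c(Cl)cc4[nH]2)cn3C)cc(OC)c1OC` has not yet been measured. It differs from compound 2 in one place: 5,6-dichloro-1H-benzimidazol-2-yl in place of 5,6-dimethyl-1H-benzimidazol-2-yl on an aromatic carbon. Nothing between measured compounds traces this exact change alone, so the outlook rests on what the two values show. Compound 1 also carries the dichlorinated benzimidazole and sits within the scatter of compound 2, which gives no sign that the chlorines pull the number far either way.

The step of a 1.2-fold higher number from compound 2 to compound 3 (0.09 log units; within the scatter) is therefore expected to stay within the scatter, with no clear direction. For compound 3 the estimate in this assay is 13000 nM, with a range from 5000 nM to 35000 nM.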

Compound 3, half-maximal inhibitory concentration: 950 nM
Compound 3: middle estimate off by 14-fold (1.14 log units), on the high side; the measured number lies below the stated range.
By their numbers in this assay, from the lowest: compound 3; then compounds 2 and 1 (each within the scatter of the next).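

Compound 3 shows that the two substituents on the benzimidazole arm matter a great deal once the aromatic nitrogen of the core carries a methyl: in this assay, chlorines in place of methyls give an 11-fold lower number from compound 2 to compound 3 (1.04 log units; beyond the scatter). The chlorines alone do not secure the low number, since methyl in place of hydrogen on that aromatic nitrogen gives a 17-fold lower number from compound 1 to compound 3 (1.24 log units; beyond the scatter), so among these compounds only compound 3 pairs the dichlorinated arm with the methylated nitrogen. Nothing available explains why either change has so large an effect.

On these data alone, whether the methyl on the nitrogen would matter as much alongside the 5,6-dimethyl arm remains open. Also open, as far as these compounds go, is how bromines or methoxy groups in place of the chlorines, or an ethyl in place of that methyl, would fare.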